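Carbamoyl for cyano: the next step in lipophilicity

This account rests on a few compounds, and the source may have more. Where it says the series, first, only, none or still open, it means among the compounds named here.

The series is followed in a physicochemical assay for lipophilicity, measured as octanol-water partition; a higher number here means a more lipophilic compound, a lower number a more polar compound. Of the compounds shown here, three have been measured. Compound 1 `CN(C)/N=N/c1ccccc1C(=O)NN` gives 1.28. Compound 2 `CN(C)/N=N/c1ccc(C#N)cc1` gives 2.39, and compound 3 `COc1ccc(C(N)=O)cc1/N=N/N(C)C` gives 0.44. Compound 2 stands highest of the three numbers; compound 1 is the nearest to it and lies lower by a gap beyond the scatter, while compound 3 is the furthest and lies lower by a still wider gap, also beyond the scatter.

The next compound, compound 4 `CN(C)/N=N/c1ccc(C(N)=O)cc1`, has not yet been measured in this assay. It differs from compound 2 in one place: carbamoyl in place of cyano on an aromatic carbon. Among the compounds with values here, no pair of measured compounds shows this same exchange in isolation, so the size of the step has to be estimated.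

A carbamoyl group is expected to bring a lower partition coefficient than a cyano group, and the step from compound 2 to compound 4 is expected to be a downward one beyond the scatter, of about a number 1.09 log units lower from compound 2 to compound 4 (beyond the scatter). Support for the direction comes from compound 3, which carries a carbamoyl and gives 0.44. Compound 4 is accordingly estimated at 1.3, with a plausible range from 0.9 to 1.7.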

Compound 4, partition coefficient: 1.2
The estimate for compound 4 lay 0.10 log units above the measured number; low and high end bracket the measured number.
By their numbers in this assay, from the lowest: compound 3; then compounds 4 and 1 (each within the scatter of the next); then compound 2.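

Carbamoyl in place of cyano on an aromatic carbon, para to a group of 5 heavy atoms, now has a measured size in this assay: the exchange brings a number 1.19 log units lower from compound 2 to compound 4 (beyond the scatter), the first step in the series that can be read at a single place, which none of the earlier compounds allowed. Cyano, with 0 hydrogen-bond donors and 1 hydrogen-bond acceptor, leaves, and carbamoyl, with 1 hydrogen-bond donor and 1 hydrogen-bond acceptor, enters; neither carries a net charge, so this large step comes with an added donor and with no change in the acceptor count or in charge. No independent measurement in hand accounts for the size of this step.

Within the data shown here, whether the exchange would give a step of similar size on another core, such as that of compound 3, remains open, since this is the only pair that shows it. Also open, on these data alone, is where an amine, a carboxylic acid or a methyl ester at this same place would stand relative to cyano and carbamoyl.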